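Iodo to isopropyl on the aromatic ring of compound 2

A few compounds are considered here, and "the series" means these few. Any claim that something is new, unique, unknown or untested is made for them only; others in the source may bear on it.

Compound 1 `O=C(CCc1cccc2c1B(O)OC2)Nc1ccccc1`: 230 nM
Compound 2 `O=C(CCc1cccc2c1B(O)OC2)Nc1cccc(I)c1`: 5300 nM
Compound 3 `CC(C)c1cccc(NC(=O)CCc2cccc3c2B(O)OC3)c1`: not yet measured

In a functional assay on MDA-MB-231 cells (Homo sapiens) for antiproliferative activity, read by MTT assay, with a stated time of 72 h (a higher number here means a weaker inhibitor, a lower number a stronger inhibitor), compound 2 gives 5300 nM, the higher of the two measured numbers. Compound 3 keeps the shared core and changes one group: isopropyl in place of iodo on an aromatic carbon. For the measured compounds named here, the only measured step bearing on this is large: a 23-fold higher number from compound 1 to compound 2 (1.36 log units; beyond the scatter), with iodo replacing hydrogen at that same place. Compound 3, like compound 2 at 5300 nM, carries a group there rather than hydrogen, so no step beyond the scatter is expected in this assay. The expected step is a 1.5-fold lower number from compound 2 to compound 3 (0.18 log units; within the scatter). Compound 3 is estimated at 3500 nM, with an expected range of 900 nM to 10000 nM.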

Compound 3, half-maximal inhibitory concentration: 1600 nM
For compound 3 the middle estimate is 2.2-fold (0.34 log units) above the measured one; the range from low to high includes it.
By their numbers in this assay, from the lowest: compound 1; then compound 3; then compound 2.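

Replacing iodo with isopropyl shows that, in this assay, the identity of the group at this place matters and not only its presence: the change gives a step beyond the scatter (a 3.3-fold lower number from compound 2 to compound 3 (0.52 log units; beyond the scatter)). Even so, isopropyl does not recover the result for hydrogen (a 7.0-fold higher number from compound 1 to compound 3 (0.84 log units; beyond the scatter)), so both groups at this aromatic carbon give higher numbers than hydrogen. Nothing measured here accounts for these differences. From the compounds shown here alone, whether an amine, a methyl or a carboxylic acid at this carbon would bring the number closer to that of compound 1 remains open. So does whether isopropyl would behave alike on another carbon of this ring.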